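A few compounds are considered here, and "the series" means these few. Any claim that something is new, unique, unknown or untested is made for them only; others in the source may bear on it.

In a functional assay on HCT-116 cells (Homo sapiens) for antiproliferative activity, read by MTT assay, with a stated time of 24 h (a higher number here means a weaker inhibitor, a lower number a stronger inhibitor), compound 1 (`COc1ccc(C(=O)/C=C/c2ccc(Br)cc2)c2c1C=CC(C)(C)O2`) gives > 10000 nM, which is a limit of the assay and not a number. Compound 2 (`COc1ccc(C(=O)/C=C/c2ccc(-c3ccccc3)cc2)c2c1C=CC(C)(C)O2`) gives > 10000 nM, again a limit. Compound 3 (`COc1ccc(C(=O)/C=C/c2ccc(C(F)(F)F)cc2)c2c1C=CC(C)(C)O2`) gives > 10000 nM, also a limit. Together these three results amount to the limit of > 10000 nM in this assay, at which 3 of the 3 values shown sit, so compound 1 has no exact position on the scale.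

The next compound, compound 4 (`COc1ccc(/C=C/C(=O)c2ccc(OC)c3c2OC(C)(C)C=C3)cn1`), alters compound 1 in one place: 6-methoxypyridin-3-yl in place of 4-bromophenyl on a double-bonded chain carbon bound to a double-bonded chain carbon.

The nearest guides are the swaps of a group on the aromatic ring, but none of them has a readable size: a step that the two limits leave unreadable from compound 1 to compound 2, a step that the two limits leave unreadable from compound 1 to compound 3 and a step that the two limits leave unreadable from compound 2 to compound 3. They offer no sign that changing this part of the molecule brings a measurable effect, although none of them installs the 6-methoxypyridin-3-yl group, so this remains a weak guide.

The expected change is a step that the limit leaves unreadable from compound 1 to compound 4, and no firm direction can be predicted for it. For compound 4 the estimate is 12000 nM, with an expected range from 3000 nM to 40000 nM.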

Compound 4, half-maximal inhibitory concentration: > 10000 nM
Compound 4: no number, only a limit (the forecaster's own chance of this, stated with the estimate: 70%); the middle value lies beyond the limit too.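

Compound 4, like compound 1, gives only a limit and not a number, so the step between them cannot be read: the limit of > 10000 nM in this assay, at which 4 of the 4 values shown sit.

From the compounds shown here alone, how these four compounds rank against one another in this assay, and which change would bring a measurable value, stays open.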